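Fluoro removal on the pyridyl ring of compound 2

This account rests on a few compounds, and the source may have more. Where it says the series, first, only, none or still open, it means among the compounds named here.

Compound 1 `Fc1cc2nc(-c3cccnc3)n(C3CC3)c2cc1F` and compound 2 `N#Cc1cc2c(cc1F)nc(-c1cncc(F)c1)n2C1CC1` share a core. In an assay on V79 cells for inhibition of cytochrome P450 11B2, mitochondrial (Homo sapiens), read by HTRF, with a stated time of 1 h (on this read-out higher numbers stand for weaker inhibition and lower numbers for stronger inhibition), compound 1 gives 2.1 nM, and compound 2 gives 1 nM, the lowest of the two numbers and beyond the scatter from compound 1. Compound 3 `N#Cc1cc2c(cc1F)nc(-c1cccnc1)n2C1CC1` differs from compound 2 by hydrogen in place of fluoro on an aromatic carbon. Within the data shown here, no measured pair shows this change, so the step from compound 2 to compound 3 is expected to be small, within the scatter, if anything toward weaker inhibition: a 1.8-fold higher number from compound 2 to compound 3 (0.26 log units; within the scatter). Compound 3 is therefore estimated at 1.8 nM, with a range from 0.7 nM to 4.5 nM.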

Compound 3, half-maximal inhibitory concentration: 0.6 nM
For compound 3 the middle estimate is 3.0-fold (0.48 log units) above the measured one; the measured number lies below the stated range.
By their numbers in this assay, from the lowest: compounds 3 and 2 (each within the scatter of the next); then compound 1.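

In this assay, 5-fluoropyridin-3-yl to pyridin-3-yl gives a 1.7-fold lower number from compound 2 to compound 3 (0.22 log units; within the scatter), so at this position the fluoro can be replaced by hydrogen with no change beyond the scatter. Compound 3 also isolates the cyano for fluoro change on an aromatic carbon, with pyridin-3-yl held constant: a 3.5-fold lower number from compound 1 to compound 3 (0.54 log units; beyond the scatter), a modest step beyond the scatter.

Going by these compounds, whether a larger group at this position, such as methoxy or an amine, would be tolerated remains open. The data offer no explanation for either step.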